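Stereochemical variation in a series without measurable inhibition

This account rests on a few compounds, and the source may have more. Where it says the series, first, only, none or still open, it means among the compounds named here.

Compound 1 `CCCCCCC(C)/C(O)=C1\C(=O)[C@@H]([C@@H](C)O)N(C)C1=O`, compound 2 `C/C=C1\C(=O)/C(=C(/O)C(C)CCCCCC)C(=O)N1C` and compound 3 `C/C=C/CCCC(C)/C(O)=C1\C(=O)[C@H]([C@H](C)O)N(C)C1=O` share one core. In a functional assay on P388 cells (Mus musculus) for inhibition, read by MTT assay, with a stated time of 24 h (on this read-out higher numbers stand for weaker inhibition and lower numbers for stronger inhibition), compound 1 gives only a limit, > 100000 nM. Compound 2 likewise gives only a limit in this assay, > 100000 nM. Compound 3 gives only a limit in this assay, > 100000 nM. Compound 3 therefore stands together with the other two at the limit of > 100000 nM in this assay, at which 3 of the 3 values shown sit, and no order among the three can be drawn from these numbers.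

Compound 4 `C/C=C/CCCC(C)/C(O)=C1\C(=O)[C@@H]([C@@H](C)O)N(C)C1=O` is not yet measured in this assay. It differs from compound 3 as follows: the two compounds have the same atoms and bonds; at least one stereo element is drawn with a configuration in one of them and without one in the other: 2 of 5 stereo elements differ; a stereocentre at a saturated ring carbon is drawn S in compound 3 and R in compound 4; a stereocentre at a saturated chain carbon is drawn S in compound 3 and R in compound 4. Going by the values given here, no measured pair in the set differs in one place, so the size of a step tied to this change is unknown from the data. The expectation is no step beyond the scatter, since the limit of > 100000 nM in this assay, at which 3 of the 3 values shown sit, is where every measured compound stands; the expected step from compound 3 to compound 4 in this assay is a number no higher from compound 3 to compound 4 (the limit leaves the size open). Compound 4 is estimated at 100000 nM, with a range from 30000 nM to 300000 nM, most likely again reported only as a limit.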

Compound 4, half-maximal inhibitory concentration: > 100000 nM
Compound 4: only a limit was reported (the forecaster's own chance of this, stated with the estimate: 80%); the middle value sits exactly at the limit.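

No step can be read from compound 3 to compound 4 or from compound 1 to compound 4, since every compound gives only a limit in this assay: the limit of > 100000 nM in this assay, at which 4 of the 4 values shown sit.

The compounds shown leave open whether the stereocentres or prop-1-en-1-yl in place of propyl bear on inhibition in this assay.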